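The source may report more compounds than this note shows. Statements on the series, on what has been measured and on what is new or still open speak of the compounds shown alone.

Compound 3, `CC(=O)NCCS(=O)(=O)NC(=O)c1ccc(Nc2nc(NC3(c4ccc(Cl)cc4)CC3)nc(OCC(F)(F)F)n2)cc1`, is the reference point for this step. In an ADME assay on microsomes from liver (Rattus norvegicus) for metabolic stability, with a stated time of 10 min (on this read-out higher numbers stand for a more stable compound and lower numbers for a less stable compound), compound 3 gives 100%, the same number at the digits shown as compound 1, `O=C(NS(=O)(=O)c1ccccc1)c1ccc(Nc2nc(NC3(c4ccc(Cl)cc4)CC3)nc(OCC(F)(F)F)n2)cc1`, which gives 100%; the two stand together at the top of the three measured values, and no change at the digits printed from compound 1 to compound 3 (within the scatter). Compound 2, `O=C(NS(=O)(=O)C1CC1)c1ccc(Nc2nc(NC3(c4ccc(Cl)cc4)CC3)nc(OCC(F)(F)F)n2)cc1`, gives 85% in this assay, and a number 15 percentage points higher from compound 2 to compound 3 (beyond the scatter), while a number 15 percentage points lower from compound 1 to compound 2 (beyond the scatter).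

Compound 4, `O=C(NS(=O)(=O)CCNCc1ccccc1)c1ccc(Nc2nc(NC3(c4ccc(Cl)cc4)CC3)nc(OCC(F)(F)F)n2)cc1`, differs from compound 3 in one place: benzyl in place of acetyl on an amine nitrogen. None of the three measured steps touches that amine nitrogen; all of them alter the group on the sulfonyl sulfur, and the whole span they cover is modest. The measured steps therefore do not speak directly to this change, and the expectation can only be cautious. Since compound 3 already stands at the top of the range seen, the estimated step is a number 15 percentage points lower from compound 3 to compound 4 (beyond the scatter), a small fall at most. Compound 4 is therefore expected to give about 85% in this assay, between 60% and 100%.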

Compound 4, percent of the compound remaining: 100%
For compound 4 the middle estimate is 15 percentage points below the measured one; the range from low to high includes it.
By their numbers in this assay, from the lowest: compound 2; then compounds 1, 3 and 4 (each within the scatter of the next).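

In this assay, going by these compounds alone, the first change at the amine nitrogen, benzyl in place of acetyl, gives no change at the digits printed from compound 3 to compound 4 (within the scatter), so a six-membered aromatic ring on that nitrogen leaves the read-out as it stood with acetyl. Within the data shown here, on the sulfonyl sulfur, 2-(benzylamino)ethyl in place of phenyl gives no change at the digits printed from compound 1 to compound 4 (within the scatter), while in place of cyclopropyl it gives a number 15 percentage points higher from compound 2 to compound 4 (beyond the scatter), so cyclopropyl remains the only group there with a step beyond the scatter. No measurement offered here explains this result.

As far as these compounds go, it remains open whether the same chain with a free amine, a tertiary amine or a carboxylic acid would hold this number. A longer chain between the sulfonyl sulfur and the amine nitrogen, or a substituted benzyl, is equally untested by these compounds.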